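The source may report more compounds than this note shows. Statements on the series, on what has been measured and on what is new or still open speak of the compounds shown alone.

Measured compounds:
compound 1, `Nc1cc(N)c2nc(-c3ccccc3)c(Oc3ccc(Cl)c(Cl)c3)nc2c1`: 6310 nM
compound 2, `COc1ccc(CNc2nc3cc(N)cc(N)c3nc2-c2ccccc2)cc1OC`: 3470 nM

Both compounds were tested in a functional assay on MOLT-4 cells (Homo sapiens) for inhibition, read by sulforhodamine B assay, with a stated time of 48 h; on this read-out lower numbers stand for stronger inhibition of growth and higher numbers for weaker inhibition of growth. On this read-out compound 1 gives 6310 nM while compound 2 gives 3470 nM; the gap between the two numbers lies within the scatter of repeated measurements, so the data do not separate them.

Compound 3, `COc1ccc(Sc2nc3cc(N)cc(N)c3nc2-c2ccccc2)cc1`, has not yet been measured in this assay. It differs from compound 1 in one place: (4-methoxyphenyl)sulfanyl in place of 3,4-dichlorophenoxy on an aromatic carbon. For the measured compounds named here, no measured pair shows what such a change does here. Going by the values given here, the only comparison available, compound 1 against compound 2, shows that a different replacement at this same position left the number within the scatter.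

With no shown step to lean on, the expected change from compound 1 to compound 3 is a 1.4-fold lower number from compound 1 to compound 3 (0.15 log units; within the scatter), no clear direction beyond the scatter. Compound 3 is thus estimated at 4500 nM, within a range of 1500 nM to 14000 nM.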

Compound 3, concentration for 50% growth inhibition: 4170 nM
Beside the measured number, compound 3's estimate is 1.1-fold (0.03 log units) above it; measured number inside the range.
By their numbers in this assay, from the lowest: compounds 2, 3 and 1 (each within the scatter of the next).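

In this assay, this position now has its first direct step: (4-methoxyphenyl)sulfanyl in place of 3,4-dichlorophenoxy gives a 1.5-fold lower number from compound 1 to compound 3 (0.18 log units; within the scatter) and so does not separate the two compounds. The change alters both the atom joining the aromatic ring to the core, oxygen to sulfur, and the substituents on that ring, yet the number stays within the scatter. Nothing given here explains this outcome.

A single step cannot show whether the two parts of the change each do little or instead cancel each other, and a 3,4-dichlorophenylsulfanyl group at this position would begin to pull them apart. On these data alone, it also remains open whether a quite different group here, such as a carboxylic acid or a short alkyl chain, would move the number beyond the scatter.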